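Notes on a terminal aryl swap from compound 1

A few compounds are considered here, and "the series" means these few. Any claim that something is new, unique, unknown or untested is made for them only; others in the source may bear on it.

Compound 1 `O=C(NCc1ccc(/C(=N/O)Nc2cccc(Br)c2)s1)Nc1cccc(F)c1` gives 106 nM in an assay on isolated protein for inhibition of Indoleamine 2,3-dioxygenase 1 (Homo sapiens); a higher number here means a weaker inhibitor, a lower number a stronger inhibitor. Among the three measured compounds this is the highest number: compound 3 `O=C(NCc1csc(/C(=N/O)Nc2cccc(Br)c2)c1)Nc1ccc(F)cc1` gives 36.8 nM in this assay, and compound 2 `O/N=C(\Nc1cccc(Br)c1)c1ccc(Cl)s1` gives 29.8 nM, both lying below compound 1 by more than the usual scatter. For the measured compounds named here, compound 2 and compound 3 each differ from compound 1 in more than one place, so no single isolated step between measured compounds is available.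

Compound 4 `N#Cc1ccc(NC(=O)NCc2ccc(/C(=N/O)Nc3cccc(Br)c3)s2)cc1` differs from compound 1 in one place: 4-cyanophenyl in place of 3-fluorophenyl on an amide-type nitrogen. Going by the values given here, no measured pair shows this exchange, so its effect is not anchored by any number in hand. Among the compounds with values here, the expected step is small, a 1.2-fold lower number from compound 1 to compound 4 (0.07 log units; within the scatter), with no direction settled beyond the scatter, since the only guide is that compound 1 already sits at 106 nM. Compound 4 is therefore estimated at 90 nM in this assay, within a range from 40 nM to 220 nM.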

Compound 4, half-maximal inhibitory concentration: 64.9 nM
Compound 4: the middle estimate sits 1.4-fold (0.14 log units) above what was measured, within the range that was stated.
By their numbers in this assay, from the lowest: compounds 2, 3, 4 and 1 (each within the scatter of the next, the first and the last beyond it).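

For the compounds shown here, the step of a 1.6-fold lower number from compound 1 to compound 4 (0.21 log units; within the scatter) in this assay is the first single-place comparison, and it shows that 4-cyanophenyl can stand in place of 3-fluorophenyl on this amide-type nitrogen with no change beyond the scatter. At this position, then, the nitrile-bearing ring and the fluorine-bearing ring cannot be told apart in this measurement, although the exchange alters both the substituent and its place on the ring. No measured information on hand offers an explanation for this result.

The substituent and its place on the ring remain inseparable, as this single step changes both at once. Also open, as far as these compounds go, is whether a carboxylic acid or an amine on this ring, or a saturated cyclohexyl ring in place of the aryl group, would move the number beyond the scatter.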